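Replacing the pyridinyl with cyclopentyl on a chromenone scaffold

The source may hold more compounds than are shown below. What is called first, only, known or untested is meant among the compounds shown, and "the series" means these compounds.

Compound 2 `O=c1cc(-c2ccncc2)oc2ccc(OCCCCCCN3CCC(O)CC3)cc12` carries the highest number of the two measured in an assay on isolated protein (Cavia porcellus) with Sigma non-opioid intracellular receptor 1 (Homo sapiens) as the target, read by radioligand binding (a higher number here means a weaker inhibitor, a lower number a stronger inhibitor), giving 308 nM, while compound 1 `COc1cccc(-c2cc(=O)c3cc(OCCCCCCN4CCC(O)CC4)ccc3o2)c1` gives 111 nM in this assay. Among the compounds with values here, the one measured step at this position, a 2.8-fold higher number from compound 1 to compound 2 (0.44 log units; beyond the scatter), was modest. Compound 3 `O=c1cc(C2CCCC2)oc2ccc(OCCCCCCN3CCC(O)CC3)cc12` introduces (cyclopentyl in place of pyridin-4-yl on an aromatic carbon). Within the data shown here, no measured step removes an aromatic group here, so the cyclopentyl change is judged by analogy only, and a modest step in this assay toward a lower number is expected. Compound 3 is therefore estimated at 150 nM in this assay, in a range from 50 nM to 500 nM, a step of a 2.1-fold lower number from compound 2 to compound 3 (0.31 log units; beyond the scatter).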

Compound 3, half-maximal inhibitory concentration: 55 nM
The estimate for compound 3 lay 2.7-fold (0.44 log units) above the measured number, within the range that was stated.
By their numbers in this assay, from the lowest: compounds 3 and 1 (each within the scatter of the next); then compound 2.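

In this assay, a non-aromatic ring at this position is compatible with the better numbers: cyclopentyl gives a 5.6-fold lower number from compound 2 to compound 3 (0.75 log units; beyond the scatter). Against the 3-methoxyphenyl group it shows a 2.0-fold lower number from compound 1 to compound 3 (0.30 log units; within the scatter), so among these three groups pyridin-4-yl alone stands apart. Nothing measured here accounts for these steps.

The compounds shown leave open how a smaller ring such as cyclopropyl, an open chain such as isopropyl or an unsubstituted phenyl would behave here. They also leave open whether an amine on the cyclopentyl ring would change the number.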